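This account rests on a few compounds, and the source may have more. Where it says the series, first, only, none or still open, it means among the compounds named here.

Measured compounds in the series:
compound 1, `COc1c(C)ccc2c1CCC2c1ncc[nH]1`, > 10000 nM in a functional assay on CHO cells for agonist activity at Alpha-1B adrenergic receptor (Homo sapiens), read by FLIPR and calcium flux; a higher number here means that more compound is needed for the effect, a lower number that less compound is needed;
compound 2, `c1cc(-c2ccn[nH]2)c2c(c1)C(c1ncc[nH]1)CC2`, 600 nM in this assay;
compound 3, `Cc1c(OCC2=NCCN2)ccc(Cl)c1NS(C)(=O)=O`, > 10000 nM in this assay.

The value of compound 1 is a limit of this assay and not a number. The value of compound 3 is likewise a limit. Within the data shown here, compound 2 thus supplies the only number in this assay, and it stands alone against two limits; two of the three results sit at the limit of > 10000 nM in this assay, at which 2 of the 3 values shown sit.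

Compound 4, `c1ccc2c(c1)CCC2c1ncc[nH]1`, has not yet been measured in this assay. It differs from compound 2 by hydrogen in place of 1H-pyrazol-5-yl on an aromatic carbon. Among the measured compounds shown here, no measured pair in the set differs in one place, so no step is on record for this change. What can be read is that the bare bicyclic core of compound 4 carries none of the substitution seen in compound 2, and that compound 1, a differently substituted version of the same core, returns only a limit.

Compound 4 is therefore expected to need more compound than compound 2, with the step from compound 2 to compound 4 estimated at an 8.3-fold higher number from compound 2 to compound 4 (0.92 log units; beyond the scatter). The estimate for compound 4 is 5000 nM, within 1000 nM to 30000 nM, with a real chance that only a limit is returned.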

Compound 4, half-maximal effective concentration: > 10000 nM
Compound 4 was reported as a limit; the forecaster's own chance of this, stated with the estimate: 40%; middle value at least 2.0-fold (0.30 log units) from the limit.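

In this assay, among these compounds, hydrogen in place of 1H-pyrazol-5-yl on this aromatic carbon gives an at least 16-fold higher number from compound 2 to compound 4 (1.22 log units; beyond the scatter), the only step on record and one that lies beyond the scatter. The earlier compounds shown here could not tie the number of compound 2 to any one place, whereas this pair does: with the 1H-pyrazol-5-yl on the aromatic carbon a number is read, and with hydrogen there only a limit is returned. Compound 2 therefore remains the only compound with a number, and the unsubstituted compound 4 joins the others at the ceiling: the limit of > 10000 nM in this assay, at which 3 of the 4 values shown sit.

Still open, going by these compounds, is whether this result is particular to the 1H-pyrazol-5-yl or would also hold for another group on the same aromatic carbon, such as an amine, a carboxylic acid or a phenyl ring. Among the compounds shown here, the result for compound 4 is a limit and not a number, so the full size of the step also remains open, and the single pair says nothing about other places on the shared core.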